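Bis(trifluoromethyl)benzenesulfonamide diamines: outlook for compound 4

The source may report more compounds than this note shows. Statements on the series, on what has been measured and on what is new or still open speak of the compounds shown alone.

Measured so far:
compound 1 `O=S(=O)(NCCNCc1cccc2ccccc12)c1cc(C(F)(F)F)cc(C(F)(F)F)c1`: 22000 nM
compound 2 `CC(C)(C)c1ccc(CNCCCNS(=O)(=O)c2cc(C(F)(F)F)cc(C(F)(F)F)c2)cc1`: 2700 nM
compound 3 `O=S(=O)(NCCCCNCc1ccc(Br)cc1)c1cc(C(F)(F)F)cc(C(F)(F)F)c1`: 2900 nM

In a functional assay on ASPC1 cells (Homo sapiens) for inhibition, read by MTT assay, with a stated time of 72 h (a higher number here means a weaker inhibitor of growth, a lower number a stronger inhibitor of growth), compound 2 gives the lowest number of the set. Compound 3 lies within the scatter of it, so no order between the two is claimed; compound 1 stands beyond the scatter and is the weaker growth inhibitor. No two of these compounds differ in a single place, so no isolated step is available. Compound 4 `O=S(=O)(NCCCNCc1ccc(Cl)c(C(F)(F)F)c1)c1cc(C(F)(F)F)cc(C(F)(F)F)c1` differs from compound 2 by 4-chloro-3-(trifluoromethyl)phenyl in place of 4-(tert-butyl)phenyl on a saturated chain carbon bound to an amine nitrogen. Within the data shown here, with no measured step for this change, the expected shift in this assay is none beyond the scatter, and the step expected is a 1.1-fold higher number from compound 2 to compound 4 (0.05 log units; within the scatter). Compound 4 is estimated at 3000 nM in this assay, with a range from 1000 nM to 9000 nM.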

Compound 4, concentration for 50% growth inhibition: 9600 nM
The estimate for compound 4 lay 3.2-fold (0.51 log units) below the measured number, and the stated range ends below it.
By their numbers in this assay, from the lowest: compounds 2 and 3 (each within the scatter of the next); then compound 4; then compound 1.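

In this assay the series gives its first single-place reading: a 3.6-fold higher number from compound 2 to compound 4 (0.55 log units; beyond the scatter) when 4-chloro-3-(trifluoromethyl)phenyl replaces 4-(tert-butyl)phenyl on a saturated chain carbon bound to an amine nitrogen. The aryl group at this place therefore matters to growth inhibition, and the two aryl groups are not interchangeable here. Nothing available accounts for the shift. Open, from the compounds shown here alone, is how 4-chlorophenyl or 3-(trifluoromethyl)phenyl alone would read at this place, as the chloro and trifluoromethyl groups enter together. Also open, going by these compounds, is whether the step holds on other chain lengths.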